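From Hydroxymethyl to 2-Hydroxyethyl on a Shared Core

A few compounds are considered here, and "the series" means these few. Any claim that something is new, unique, unknown or untested is made for them only; others in the source may bear on it.

Compound 2 `OC[C@@H]1O[C@H](COCc2ccccc2)[C@@H](OCc2ccccc2)[C@H](OCc2ccccc2)[C@H]1O` gives 27300 nM in a functional assay on HOS cells (Homo sapiens) for antiproliferative activity, read by sulforhodamine B assay (on this read-out higher numbers stand for weaker inhibition of growth and lower numbers for stronger inhibition of growth), and compound 1 `CCCC[C@@H]1O[C@H](COCc2ccccc2)[C@@H](OCc2ccccc2)[C@H](OCc2ccccc2)[C@H]1O` gives 40100 nM there, so the two stand level within the usual scatter and neither pulls ahead on these numbers. Compound 3 `OCC[C@@H]1O[C@H](COCc2ccccc2)[C@@H](OCc2ccccc2)[C@H](OCc2ccccc2)[C@H]1O` shares the core of both but has not yet been measured. It differs from compound 2 as follows: hydroxymethyl in place of hydroxy on a saturated chain carbon bound to a saturated ring carbon and in plain words this is hydroxymethyl in place of hydroxy on a saturated chain carbon bound to a saturated ring carbon, the same difference that reads hydroxymethyl to 2-hydroxyethyl. Within the data shown here, the only measured step that bears on this is a 1.5-fold lower number from compound 1 to compound 2 (0.17 log units; within the scatter) and it puts hydroxy in place of propyl at that same kind of carbon, so no step beyond the scatter is expected for compound 3 in this assay on this slim evidence. The estimate amounts to a 1.1-fold higher number from compound 2 to compound 3 (0.04 log units; within the scatter) as the expected change. Compound 3 is expected at 30000 nM with an estimated range from 15000 nM to 60000 nM for now.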

Compound 3, concentration for 50% growth inhibition: 39700 nM
Compound 3: middle estimate off by 1.3-fold (0.12 log units), on the low side; the range from low to high includes it.
By their numbers in this assay, from the lowest: compounds 2, 3 and 1 (each within the scatter of the next).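

In this assay, going from hydroxymethyl to 2-hydroxyethyl gives a 1.5-fold higher number from compound 2 to compound 3 (0.16 log units; within the scatter), so this extension of the hydroxy-bearing chain brings no change that can be told apart from repeat-to-repeat noise. Hydroxy in place of ethyl on a saturated chain carbon, two bonds along the chain from a saturated ring carbon, gives a 1.0-fold lower number from compound 1 to compound 3 (0.00 log units; within the scatter), which means that a chain ending in hydroxy and the all-carbon chain of compound 1 also stand level at this chain length. Compounds 1, 2 and 3 therefore all lie within the scatter of one another, so the three side chains shown on this carbon cannot be ranked, and no measurement at hand offers a reason for that flat picture.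

As far as these compounds go, whether an amine or a carboxylic acid at the end of this chain, or a longer chain ending in hydroxy, would move the number beyond the scatter stays open. The rest of the shared core is the same in all three compounds, so these results speak only for this one position on that core.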